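The source may report more compounds than this note shows. Statements on the series, on what has been measured and on what is new or still open speak of the compounds shown alone.

Measured so far:
compound 1 `COc1cc(-c2cc(/C=C/C(=O)c3ccc(N)cc3)[nH]n2)cc(OC)c1OC` — 6190 nM
compound 2 `COc1ccc(-c2cc(/C=C/C(=O)c3ccc(OC)c(OC)c3)[nH]n2)cc1` — 6080 nM

In a functional assay on HCT-116 cells (Homo sapiens) for inhibition, read by sulforhodamine B assay, with a stated time of 48 h (on this read-out higher numbers stand for lower toxicity in this test and lower numbers for higher toxicity in this test), compound 1 gives 6190 nM, and compound 2 gives 6080 nM; the two numbers sit within the scatter of each other, so no order between them can be read. Compound 3 `COc1cc(-c2cc(/C=C/C(=O)c3ccc(F)c(F)c3)[nH]n2)cc(OC)c1OC` is not yet measured. It differs from compound 1 in one place: 3,4-difluorophenyl in place of 4-aminophenyl on a carbonyl carbon. For the measured compounds named here, no measured pair shows what such a change does here. The step from compound 1 to compound 3 is expected to be small, none beyond the scatter, a 1.0-fold lower number from compound 1 to compound 3 (0.01 log units; within the scatter). For compound 3 the value in this assay is estimated at 6000 nM, within 2500 nM to 15000 nM.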

Compound 3, concentration lethal to 50% of the cells: 94200 nM
Estimate against measurement, compound 3: 16-fold (1.20 log units) below, and the stated range ends below it.
By their numbers in this assay, from the lowest: compounds 2 and 1 (each within the scatter of the next); then compound 3.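

In this assay the place on the carbonyl carbon proves sensitive to the group it carries: 3,4-difluorophenyl in place of 4-aminophenyl gives a 15-fold higher number from compound 1 to compound 3 (1.18 log units; beyond the scatter) and so moves the value well beyond the scatter. Compound 1 and compound 2 alone could not show this, since they differ in more than one place. Nothing measured on these compounds accounts for the step.

Still open, from the compounds shown here alone, is whether the step follows from the amine leaving or from the fluorines entering. A 4-fluorophenyl or a 4-(dimethylamino)phenyl group in this place would help to separate the two.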